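A few compounds are considered here, and "the series" means these few. Any claim that something is new, unique, unknown or untested is made for them only; others in the source may bear on it.

Compound 3 `NC(=S)c1cn(C2OC(CO)CC2O)c2ncnc(N)c12` gives 600 nM in a functional assay on L1210 cells (Mus musculus) for inhibition (on this read-out lower numbers stand for stronger inhibition and higher numbers for weaker inhibition), the second highest of the three numbers measured. Among the compounds with values here, its nearest neighbour is compound 1 `N#Cc1cn(C2OC(CO)CC2O)c2ncnc(N)c12`, which gives 100 nM; the step of a 6.0-fold higher number from compound 1 to compound 3 (0.78 log units; beyond the scatter) is the only measured step, and it concerns the group on the aromatic carbon, not the five-membered non-aromatic ring. Compound 2 `N#Cc1cn([C@@H]2O[C@H](CO)[C@@H](O)[C@@H]2N)c2ncnc(N)c12` gives 100000 nM. Compound 4 `NC(=S)c1cn(C2CCC(CO)O2)c2ncnc(N)c12` differs from compound 3 by hydrogen in place of hydroxy on a saturated ring carbon. Within the data shown here, no measured step involves that ring, so nothing here bears directly on this change, and the expectation is a weakening with a wide range. Compound 4 is therefore estimated at 12000 nM in this assay, between 1500 nM and 100000 nM, meaning an expected step of a 20-fold higher number from compound 3 to compound 4 (1.30 log units; beyond the scatter).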

Compound 4, half-maximal inhibitory concentration: 24000 nM
For compound 4 the middle estimate is 2.0-fold (0.30 log units) below the measured one; measured number inside the range.
By their numbers in this assay, from the lowest: compound 1; then compound 3; then compound 4; then compound 2.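

The hydroxy on the saturated ring carbon carries much weight in this assay (a 40-fold higher number from compound 3 to compound 4 (1.60 log units; beyond the scatter)), a large step set against the modest one on the aromatic carbon (a 6.0-fold higher number from compound 1 to compound 3 (0.78 log units; beyond the scatter)). Within the data shown here, this is the first measured step at the ring, and it shows that replacing this hydroxy by hydrogen weakens inhibition far beyond the scatter. No evidence is available on why the step is so large.

On these data alone, whether fluorine or a methoxy group at this ring carbon would keep any of the inhibition stays open. So does whether the same change would weigh as heavily alongside the nitrile of compound 1.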